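Fluoro for cyano on the aryl ring of a dihydropyridine

A few compounds are considered here, and "the series" means these few. Any claim that something is new, unique, unknown or untested is made for them only; others in the source may bear on it.

Compound 1 `COC(=O)C1=C(C)N=C(C)/C(=C(\O)OC)C1c1cc([N+](=O)[O-])ccc1O` — 100 nM
Compound 2 `COC(=O)C1=C(C)N=C(C)/C(=C(\O)OC)C1c1cccc(OC(=O)c2ccccc2)c1` — 6310 nM
Compound 3 `COC(=O)C1=C(C)N=C(C)/C(=C(\O)OC)C1c1ccccc1C#N` — 15.9 nM

In a functional assay (muscle tissue) with Cavia porcellus as the target (a lower number here means that less compound is needed, a higher number that more compound is needed for the effect), compound 3 gives the lowest of the three numbers. Compound 1 sits above it by a gap beyond the scatter, and compound 2 lies far higher still. Compound 4 `COC(=O)C1=C(C)N=C(C)/C(=C(\O)OC)C1c1ccccc1F` differs from compound 3 in one place: fluoro in place of cyano on an aromatic carbon. The group that leaves carries an acceptor, the group that enters carries none, and the three measured compounds give no direct read on such a swap. A modest rise in the number is expected, likely near the edge of the scatter, so the step from compound 3 to compound 4 is estimated as a 3.1-fold higher number from compound 3 to compound 4 (0.50 log units; beyond the scatter). Compound 4 is therefore expected to give about 50 nM, within 10 nM to 250 nM.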

Compound 4, half-maximal effective concentration: 42.7 nM
Compound 4: middle estimate off by 1.2-fold (0.07 log units), on the high side; the range from low to high includes it.
By their numbers in this assay, from the lowest: compound 3; then compound 4; then compound 1; then compound 2.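

In this assay the swap of cyano for fluoro, ortho to a large group, gives a 2.7-fold higher number from compound 3 to compound 4 (0.43 log units; beyond the scatter) as the first direct read on this position, a modest step. The 2-fluorophenyl group, with no hydrogen-bond acceptor counted, therefore stays fairly close to the 2-cyanophenyl group, although the two remain distinguishable. Nothing at hand bears on why the number rises. The compounds shown leave open how an amine, a methoxy group or a carboxylic acid at this same place would compare, and whether this step holds elsewhere on the aromatic ring.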